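Piperidinyl in place of butylamino: cytotoxicity expectation

This account rests on a few compounds, and the source may have more. Where it says the series, first, only, none or still open, it means among the compounds named here.

Compound 1: `CC(C)Nc1nc2cc(Cl)ccc2c(=O)[nH]1`; in an ADME assay on Vero cells (Chlorocebus sabaeus) for cytotoxicity, read by WST assay (a higher number here means that more compound is tolerated, a lower number that less compound is tolerated), compound 1 gives > 25000 nM, a limit of the assay.
Compound 2: `CCCCNc1nc2cc(Cl)ccc2c(=O)[nH]1`; in this assay compound 2 gives > 25000 nM, again a limit of the assay.

Compound 2 therefore stands at a limit in this assay rather than at a measured number, and the other value shown is a limit too. Among the compounds with values here, the one step between measured compounds, a step that the two limits leave unreadable from compound 1 to compound 2, cannot be read in size because of the limit of > 25000 nM in this assay, at which 2 of the 2 values shown sit.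

Compound 3, `O=c1[nH]c(N2CCCCC2)nc2cc(Cl)ccc12`, differs from compound 2 in one place: piperidin-1-yl in place of butylamino on an aromatic carbon. Within the data shown here, the only measured step bears on it merely in showing that an alkylamino change on the shared core left both compounds at the limit. On that basis no step beyond the scatter is expected in this assay from compound 2 to compound 3, and the estimated step that the limit leaves unreadable from compound 2 to compound 3 simply carries compound 3 to the same region. Compound 3 is thus expected to give about 30000 nM, with a range from 10000 nM to 100000 nM, most likely reported again as a limit.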

Compound 3, half-maximal cytotoxic concentration: > 25000 nM
Compound 3: a limit, no number; the forecaster's own chance of this, stated with the estimate: 75%; the middle value does not contradict the limit.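

In this assay compound 3 gives > 25000 nM, again a limit of the assay and not a number. Neither step to compound 3, from compound 1 or from compound 2, can be read in size, because of what all three compounds share: the limit of > 25000 nM in this assay, at which 3 of the 3 values shown sit. The compounds shown leave open whether isopropylamino, butylamino and piperidin-1-yl on the shared core differ in cytotoxicity at all.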